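Anilide variation on the benzyl-substituted core

This account rests on a few compounds, and the source may have more. Where it says the series, first, only, none or still open, it means among the compounds named here.

Compound 2 `Cc1ccc(F)cc1NC(=O)CN1CCN(c2nnc(Cc3ccccc3)c3ccccc23)CC1` carries a 5-fluoro-2-methylphenyl amide and gives "not active" (no number reported) in a functional assay on A549 cells (Homo sapiens) for cytotoxicity, read by MTT assay, with a stated time of 72 h (a higher number here means a weaker inhibitor, a lower number a stronger inhibitor), so no number places it among the others. For the measured compounds named here, compound 1 `O=C(CN1CCN(c2nnc(Cc3ccncc3)c3ccccc23)CC1)Nc1ccc(F)c(F)c1` gives 3790 nM and compound 3 `O=C(CN1CCN(c2nnc(Cc3ccncc3)c3ccccc23)CC1)Nc1cccc(Br)c1` gives 1530 nM; the only measured step, a 2.5-fold lower number from compound 1 to compound 3 (0.39 log units; beyond the scatter), is a change of the aryl amide on a different core. Compound 4 `Cc1ccc(NC(=O)CN2CCN(c3nnc(Cc4ccccc4)c4ccccc34)CC2)c(C)c1` differs from compound 2 by 2,4-dimethylphenyl in place of 5-fluoro-2-methylphenyl on an amide-type nitrogen. The measured step bears on it only loosely, as a change of the same kind at the same place, and its size suggests a modest shift at most. With compound 2 inactive, compound 4 is expected to remain weak, estimated at 20000 nM with a range of 5000 nM to 80000 nM.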

Compound 4, half-maximal inhibitory concentration: "not active" (no number reported)
Compound 4: no number reported; no gap can be computed for the estimate.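

Compound 2 and compound 4 both read "not active" in this assay and give no number, so no step can be read between them. No evidence bears on this result. The compounds shown leave open whether any anilide on this benzyl-substituted core gives a measurable value.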